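The source may hold more compounds than are shown below. What is called first, only, known or untested is meant among the compounds shown, and "the series" means these compounds.

Values in a functional assay on HT cells (Homo sapiens) for antiproliferative activity, read by fluorescence, with a stated time of 72 h; on this read-out higher numbers stand for weaker inhibition of growth and lower numbers for stronger inhibition of growth:
- compound 1 `CC(C)c1n[nH]c2c(NCc3ccc(-c4ccccn4)cc3)nc(SCC(O)CO)nc12`: 21 nM
- compound 2 `CC(O)CSc1nc(NCc2ccc(-c3ccccn3)cc2)c2[nH]nc(C(C)C)c2n1`: 62 nM
- compound 3 `CC(C)c1n[nH]c2c(NCc3ccc(-c4ccccn4)cc3)nc(SCC(C)(C)N)nc12`: 85 nM

Going by the values given here, compound 3 lies at the upper end of the numbers so far. The measured steps into it are a 4.0-fold higher number from compound 1 to compound 3 (0.61 log units; beyond the scatter) and a 1.4-fold higher number from compound 2 to compound 3 (0.14 log units; within the scatter).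

Compound 4 `CC(C)c1n[nH]c2c(NCc3ccc(-c4ccccn4)cc3)nc(SCCNC(N)=O)nc12` carries ureidomethyl in place of 1-amino-1-methylethyl on a saturated chain carbon bound to a sulfur.

All three measured steps are changes on this same chain, and the remaining one is a 3.0-fold higher number from compound 1 to compound 2 (0.47 log units; beyond the scatter). None exceeds a modest size, but none of them introduces a ureido group, so the data set no firm direction. In this assay, a small change is therefore expected, with at most a slight lean towards stronger inhibition of growth, as compound 3 already sits at the upper end.

The expected change is a 1.4-fold lower number from compound 3 to compound 4 (0.15 log units; within the scatter).

For compound 4 the estimated value is 60 nM, with an expected range of 20 nM to 180 nM.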

Compound 4, concentration for 50% growth inhibition: 240 nM
Compound 4: middle estimate off by 4.0-fold (0.60 log units), on the low side; measured number outside the range, above it.
By their numbers in this assay, from the lowest: compound 1; then compounds 2 and 3 (each within the scatter of the next); then compound 4.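

In this assay, going by these compounds alone, the chain on the sulfur can move the number much further than the earlier compounds showed: an 11-fold higher number from compound 1 to compound 4 (1.06 log units; beyond the scatter) is a large step, where none before it went beyond a modest size. Both a 2.8-fold higher number from compound 3 to compound 4 (0.45 log units; beyond the scatter) and a 3.9-fold higher number from compound 2 to compound 4 (0.59 log units; beyond the scatter) lie beyond the scatter, so the (2-ureidoethyl)sulfanyl chain stands apart from all three other chains, on the side of weaker inhibition of growth. Nothing at hand explains this shift.

Open is whether the shift goes with the carbonyl of the ureido group or with the unbranched chain that carries it; a 2-aminoethyl or 2-acetamidoethyl chain does not stand among the compounds shown. Going by these compounds, how a longer chain ending in a ureido group would read also remains open.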